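This account rests on a few compounds, and the source may have more. Where it says the series, first, only, none or still open, it means among the compounds named here.

Compound 1 `S=C=Nc1ccc(CCC2=NCCN2)cc1` gives 102%.
Compound 2 `Cc1ccc(CC2=NCCN2)cc1` gives 5%.
Compound 3 `S=C=Nc1ccc(Cc2ncc[nH]2)cc1` gives 68%.

In an ADME assay on the whole organism (thoracic aorta) with Rattus norvegicus as the target (a higher number here means a larger maximal response, a lower number a smaller maximal response), compound 2 stands lowest of the three numbers; its gap to compound 3 and its larger gap to compound 1 both lie beyond the scatter. Compound 4 `Nc1ccc(CC2=NCCN2)cc1` is the untested member of the set. It differs from compound 2 in one place: amino in place of methyl on an aromatic carbon. Within the data shown here, no pair of measured compounds shows this same change, so the size of the step cannot be read from the data. Given that compound 2 gives 5%, a moderate rise is expected, but not one reaching the highest numbers in this assay. The step from compound 2 to compound 4 is estimated as a number 20 percentage points higher from compound 2 to compound 4 (beyond the scatter). Compound 4 is expected to give about 25%, between 5% and 60%.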

Compound 4, largest response reached (Emax), in percent of the reference or control that the assay uses: 9%
Beside the measured number, compound 4's estimate is 16 percentage points above it; low and high end bracket the measured number.
By their numbers in this assay, from the lowest: compounds 2 and 4 (each within the scatter of the next); then compound 3; then compound 1.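

In this assay, amino in place of methyl on an aromatic carbon gives a number 4 percentage points higher from compound 2 to compound 4 (within the scatter), so at this position this read-out does not tell the two groups apart. The hydrogen-bond donor and acceptor counted for amino thus bring no step beyond the scatter on this core. No available measurement bears on this result. On these data alone, whether a nitrile, a carboxylic acid or a longer chain at this position would give a step beyond the scatter stays open. So does the size of the same amino-for-methyl change on the cores of compound 1 and compound 3.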